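The compounds below may be only part of what the source reports. "The series", "measured", "known", "first", "only" and "open" are said of these compounds alone.

Compound 3 `COc1cc(OC)c2c(=O)cc(-c3ccc(OCCCN)cc3)oc2c1` gives 39% in a functional assay (Homo sapiens) for antiproliferative activity, read by resazurin assay, with a stated time of 48 h, tested at 10 uM; a higher number here means a stronger effect of the compound at the concentration tested, a lower number a weaker effect. Among the three measured compounds it stands second highest: compound 2 `COc1cc(OC)c2c(=O)cc(-c3ccc(OCCN)cc3)oc2c1` gives 35%, and the step of a number 4 percentage points higher from compound 2 to compound 3 (within the scatter) lies within the scatter, while compound 1 `COc1cc(OC)c2c(=O)cc(-c3ccc(OCCCN(C)C)cc3)oc2c1` gives 59%, and the step of a number 20 percentage points lower from compound 1 to compound 3 (beyond the scatter) lies beyond it. Compound 4 `COc1cc(OC)c2c(=O)cc(-c3ccc(OCC(O)CN4CCCC4)cc3)oc2c1` differs from compound 3 in one place: 1-hydroxy-2-(pyrrolidin-1-yl)ethyl in place of 2-aminoethyl on a saturated chain carbon bound to an oxygen on an aromatic ring. Among the measured compounds shown here, the steps that bear on this are a number 24 percentage points lower from compound 1 to compound 2 (beyond the scatter) and a number 20 percentage points lower from compound 1 to compound 3 (beyond the scatter), both of them swaps of a dimethylamino group for a plain amino group, and both modest. Compound 4 brings back a nitrogen carrying two carbons, here as a pyrrolidin-1-yl group, so a modest rise is expected, a number 13 percentage points higher from compound 3 to compound 4 (beyond the scatter). For compound 4 the estimate is 52%, expected to fall between 36% and 68%.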

Compound 4, a percentage reported as inhibition, at one concentration (the size of the read-out at that concentration, not a potency): 37%
Beside the measured number, compound 4's estimate is 15 percentage points above it, and the stated range covers the measured number.
By their numbers in this assay, from the lowest: compounds 2, 4 and 3 (each within the scatter of the next); then compound 1.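

In this assay, the swap to 2-hydroxy-3-(pyrrolidin-1-yl)propoxy gives a number 2 percentage points lower from compound 3 to compound 4 (within the scatter) and, against the shorter amine, a number 2 percentage points higher from compound 2 to compound 4 (within the scatter). Ending the chain in a pyrrolidin-1-yl group therefore does not restore the level of compound 1, as the gap shows: a number 22 percentage points lower from compound 1 to compound 4 (beyond the scatter). Nothing available explains this result. The change adds both a hydroxy group and a ring, and these compounds cannot separate the two. Also open, going by these compounds, is how a plain 3-(pyrrolidin-1-yl)propoxy chain, or a piperidine or morpholine on the same chain, would compare.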